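The source may hold more compounds than are shown below. What is called first, only, known or untested is meant among the compounds shown, and "the series" means these compounds.

Of the compounds shown here, three from this series have been tested in a functional assay on HCT-116 cells (Homo sapiens) for cytotoxicity, read by MTT assay, with a stated time of 48 h, in the presence of a further agent that is not named here; on this read-out lower numbers stand for an effect already at smaller amounts and higher numbers for an effect only at larger amounts of compound. Compound 1 `CC(C)c1cc(NNC(=O)Nc2cc(Cl)nc(Cl)c2)nc2c1c(C(F)(F)F)nn2C` gives 27200 nM in this assay. Compound 2 `Cn1ncc2c(-c3ccc(F)cc3)cc(NNC(=O)Nc3cc(Cl)nc(OCCF)c3)nc21` gives 37200 nM in this assay. Compound 3 `Cc1nn(C)c2nc(NNC(=O)Nc3cc(Cl)nc(Cl)c3)cc(-c3ccc(F)cc3)c12` gives 25200 nM in this assay. Of the three numbers, that of compound 3 is the smallest, yet its distance to compound 1 and its distance to compound 2 both fall within the usual scatter of repeated measurements, so the three compounds behave alike on this read-out and no order among them can be claimed.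

Compound 4 `Cc1nn(C)c2nc(NNC(=O)Nc3cc(Cl)nc(Cl)c3)cc(C3CCCCC3)c12` has not yet been measured. It differs from compound 3 in one place: cyclohexyl in place of 4-fluorophenyl on an aromatic carbon. Within the data shown here, no step between two measured compounds isolates this exchange, so nothing in the data shows how an aromatic ring giving way to a non-aromatic ring at this position affects the number. Compound 1, which also carries a non-aromatic group at the corresponding place alongside other differences, sits close to compound 3, which argues for a small step at most. The step from compound 3 to compound 4 in this assay is therefore expected to be a 1.2-fold higher number from compound 3 to compound 4 (0.08 log units; within the scatter), a change not beyond the scatter in either direction. Compound 4 is estimated at 30000 nM in this assay, within a range from 12000 nM to 75000 nM.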

Compound 4, half-maximal effective concentration: 38000 nM
For compound 4 the middle estimate is 1.3-fold (0.10 log units) below the measured one, and the stated range covers the measured number.
By their numbers in this assay, from the lowest: compounds 3, 1, 2 and 4 (each within the scatter of the next).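

In this assay, putting cyclohexyl in place of 4-fluorophenyl on the aromatic carbon opposite the ring nitrogen gives a 1.5-fold higher number from compound 3 to compound 4 (0.18 log units; within the scatter). Among these compounds, this is the first step that isolates a single place, and it shows that, on this read-out, a six-membered non-aromatic ring of carbon at this position cannot be told apart from the fluorinated aromatic ring it replaces, so an aromatic ring here is not required to keep the number where it stands. Nothing available bears on why the exchange leaves the number within the scatter.

The exchange removes the aromatic ring and the fluorine together, so a plain phenyl group would be needed to separate the two, and the step says nothing about whether either change alone would matter. It also leaves open whether a much smaller group such as methyl, or a ring or chain carrying an amine or a carboxylic acid, would move the number beyond the scatter at this position.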